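Halogen swap on the hydrazone aryl of compound 1

This account rests on a few compounds, and the source may have more. Where it says the series, first, only, none or still open, it means among the compounds named here.

Compound 1 `CN(C)CCn1cnnc1-c1cc(Oc2ccc(NC(=O)N/N=C/c3ccc(Cl)cc3)cc2F)ccn1` was tested in a functional assay on NCI-H460 cells (Homo sapiens) for cytotoxicity, read by MTT assay, with a stated time of 72 h (on this read-out higher numbers stand for weaker inhibition and lower numbers for stronger inhibition), where compound 1 gives 320 nM. On the numbers measured, compound 1 stands lowest of the three: compound 3 `CN(C)CCn1cnnc1-c1cc(Oc2ccc(NC(=O)N/N=C/c3ccc(O)cc3)cc2F)ccn1` gives 1780 nM and compound 2 `CN(C)CCn1cnnc1-c1cc(Oc2ccc(NC(=O)N/N=C/c3ccc(O)c(O)c3)cc2F)ccn1` gives 1930 nM. The step of a 5.6-fold higher number from compound 1 to compound 3 (0.75 log units; beyond the scatter) and the step of a 6.0-fold higher number from compound 1 to compound 2 (0.78 log units; beyond the scatter) both lie beyond the scatter, while a 1.1-fold lower number from compound 2 to compound 3 (0.04 log units; within the scatter) lies within it.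

Compound 4 `CN(C)CCn1cnnc1-c1cc(Oc2ccc(NC(=O)N/N=C/c3ccc(F)cc3F)cc2F)ccn1` differs from compound 1 in one place: 2,4-difluorophenyl in place of 4-chlorophenyl on a carbon with a double bond to nitrogen. Among the compounds with values here, no measured step is a halogen-for-halogen swap at this position; the two steps that bear on this carbon, a 6.0-fold higher number from compound 1 to compound 2 (0.78 log units; beyond the scatter) and a 5.6-fold higher number from compound 1 to compound 3 (0.75 log units; beyond the scatter), both introduce a hydroxy group and are modest in size. Compound 4 keeps a halogenated phenyl with no hydrogen-bond donors or acceptors, so the weakening seen with hydroxy is not expected to carry over. A step no larger than the scatter, or a little weaker, is expected for a 1.4-fold higher number from compound 1 to compound 4 (0.15 log units; within the scatter). Compound 4 is therefore estimated at 450 nM, with a range from 200 nM to 1000 nM.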

Compound 4, half-maximal inhibitory concentration: 1930 nM
The estimate for compound 4 lay 4.3-fold (0.63 log units) below the measured number; measured number above the stated range.
By their numbers in this assay, from the lowest: compound 1; then compounds 3, 2 and 4 (each within the scatter of the next).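

In this assay, the new step (a 6.0-fold higher number from compound 1 to compound 4 (0.78 log units; beyond the scatter)) shows that the higher number at this carbon does not depend on a hydroxy group, since the entering 2,4-difluorophenyl has 0 hydrogen-bond donors and is itself halogenated. Compound 4 also cannot be separated from the two hydroxylated compounds (a 1.1-fold higher number from compound 3 to compound 4 (0.04 log units; within the scatter); no change at the digits printed from compound 2 to compound 4 (within the scatter)), so among the four compounds shown, only the 4-chlorophenyl of compound 1 stands apart, beyond the scatter from each of the other three, while the 2,4-difluorophenyl, 4-hydroxyphenyl and 3,4-dihydroxyphenyl groups give numbers within the scatter of one another. No measurement is available to explain why the 4-chlorophenyl group differs from the other three groups on this carbon.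

The compounds shown leave open whether the lower number of compound 1 belongs to chlorine specifically or to a single halogen on the ring, which a 4-fluorophenyl or a 4-bromophenyl group would help to separate. They also leave open whether the second fluorine in compound 4 matters, and how a 4-methylphenyl or a 2-chlorophenyl group would compare at this carbon.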